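Cytotoxicity Expectation for a Methoxy-for-Chloro Exchange

A few compounds are considered here, and "the series" means these few. Any claim that something is new, unique, unknown or untested is made for them only; others in the source may bear on it.

Compound 2 `Cc1cc(-c2cccc(Cl)c2)cc(C)c1Nc1ccnc(Nc2ccc(C#N)cc2)n1` gives 2160 nM in an ADME assay on MT4 cells (Homo sapiens) for cytotoxicity, read by MTT assay, with a stated time of 4 days; on this read-out higher numbers stand for lower toxicity in this test and lower numbers for higher toxicity in this test. Among the two compounds measured so far it holds the lowest number, but its nearest neighbour, compound 1 `Cc1cc(-c2ccccc2C(F)(F)F)cc(C)c1Nc1ccnc(Nc2ccc(C#N)cc2)n1`, gives 4210 nM, and the step of a 1.9-fold lower number from compound 1 to compound 2 (0.29 log units; within the scatter) lies within the scatter, so the two compounds cannot be told apart on this read-out. Compound 3 `COc1cccc(-c2cc(C)c(Nc3ccnc(Nc4ccc(C#N)cc4)n3)c(C)c2)c1` is not yet measured. It differs from compound 2 by methoxy in place of chloro on an aromatic carbon, a change on the same pendant aromatic ring that was altered between compound 1 and compound 2. Among the measured compounds shown here, that single earlier step, a 1.9-fold lower number from compound 1 to compound 2 (0.29 log units; within the scatter), is the only one that bears on the new exchange, and it stayed within the scatter; no step that swaps chloro for methoxy has been measured in this set. With nothing in the data reaching beyond the scatter, compound 3 is expected to show essentially no shift, a 1.2-fold higher number from compound 2 to compound 3 (0.06 log units; within the scatter), in this assay. The estimate for compound 3 in this assay is therefore 2500 nM, within a range from 1000 nM to 7000 nM.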

Compound 3, half-maximal cytotoxic concentration: 2990 nM
For compound 3 the middle estimate is 1.2-fold (0.08 log units) below the measured one, and the stated range covers the measured number.
By their numbers in this assay, from the lowest: compounds 2, 3 and 1 (each within the scatter of the next).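

In this assay, methoxy in place of chloro on an aromatic carbon, meta to a large group, gives a 1.4-fold higher number from compound 2 to compound 3 (0.14 log units; within the scatter). This exchange therefore does not separate the two compounds, even though the chloro that leaves carries no hydrogen-bond acceptor and the methoxy that enters carries one. Replacing the 2-(trifluoromethyl)phenyl group with 3-methoxyphenyl gives a 1.4-fold lower number from compound 1 to compound 3 (0.15 log units; within the scatter), so the three aromatic groups now compared on this read-out, 2-(trifluoromethyl)phenyl, 3-chlorophenyl and 3-methoxyphenyl, cannot be told apart, and no measurement is at hand that would account for this.

The compounds shown leave open whether an amine, a carboxylic acid or a longer chain at this same place would produce a step beyond the scatter, or whether the read-out would stay as flat as it has across these three groups. They also leave open whether a group other than these on the same ring, placed elsewhere than meta to the large group, would move the number in this assay.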